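This account rests on a few compounds, and the source may have more. Where it says the series, first, only, none or still open, it means among the compounds named here.

Measured compounds in a functional assay on CHO cells for agonist activity at metabotropic glutamate receptor 2 (Homo sapiens), read by GTPgammaS binding; on this read-out lower numbers stand for an effect already at smaller amounts and higher numbers for an effect only at larger amounts of compound:
compound 1 `CCCn1ccc2cc(-c3cccnc3)cc(Cl)c2c1=O`, 631 nM
compound 2 `CCCn1ccc2cc(-c3cccnc3)ccc2c1=O`, 7940 nM

Compound 2 stands highest of the two numbers shown; its nearest neighbour is compound 1, a step of a 13-fold higher number from compound 1 to compound 2 (1.10 log units; beyond the scatter) apart. Within the data shown here, compound 3 `CCCn1ccc2cc(-c3cccnc3)cc(C#N)c2c1=O` differs from compound 2 by cyano in place of hydrogen on an aromatic carbon, the same position at which chloro was removed in the step of a 13-fold higher number from compound 1 to compound 2 (1.10 log units; beyond the scatter), the one measured step that bears on it. Occupying that aromatic carbon with cyano is therefore expected to move this assay downward, though the size is uncertain. For compound 3 the estimate is 1000 nM, range 300 nM to 3500 nM, an expected step of a 7.9-fold lower number from compound 2 to compound 3 (0.90 log units; beyond the scatter).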

Compound 3, half-maximal effective concentration: > 50100 nM
Compound 3: a limit, no number; the forecaster's own chance of this, stated with the estimate: 5%; at least 50-fold (1.69 log units) between middle value and limit.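

In this assay, occupying this aromatic carbon does not by itself lower the number: the outcome depends on the group, with an at least 79-fold higher number from compound 1 to compound 3 (1.89 log units; beyond the scatter). Cyano in place of hydrogen moves the number the opposite way from chloro in place of hydrogen, with an at least 6.3-fold higher number from compound 2 to compound 3 (0.80 log units; beyond the scatter). The result for compound 3 is a limit of the assay and not a number: the limit of > 50100 nM in this assay, at which 1 of the 3 values shown sits.

The compounds shown leave open where other groups on this carbon, such as fluoro, bromo, methyl or methoxy, would fall relative to chloro and cyano. On these data alone, the full size of the cyano step also stays open, with only its lower bound given.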